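The source may hold more compounds than are shown below. What is called first, only, known or untested is meant among the compounds shown, and "the series" means these compounds.

Measured so far:
- compound 1 `Brc1ccc2[nH]cc(C(c3ccccc3)c3c[nH]c4ccc(Br)cc34)c2c1`: 7500 nM
- compound 2 `Brc1ccc2[nH]cc(C(c3ccc4ccccc4c3)c3c[nH]c4ccc(Br)cc34)c2c1`: 8500 nM

In a functional assay on A549 cells (Homo sapiens) for inhibition, read by MTT assay, with a stated time of 48 h (on this read-out higher numbers stand for weaker inhibition and lower numbers for stronger inhibition), compound 2 gives 8500 nM, within the scatter of compound 1. Compound 3 `Clc1ccc(C(c2c[nH]c3ccc(Br)cc23)c2c[nH]c3ccc(Br)cc23)cc1` has 4-chlorophenyl in place of naphthalen-2-yl on a saturated chain carbon bound to two aromatic carbons. Among the compounds with values here, one measured step bears on this change: a 1.1-fold higher number from compound 1 to compound 2 (0.05 log units; within the scatter), which put naphthalen-2-yl in place of phenyl on that same carbon. Within the data shown here, with only this step to go on, no change beyond the scatter is expected in this assay. The expected step is a 1.2-fold lower number from compound 2 to compound 3 (0.08 log units; within the scatter). Compound 3 is estimated at 7000 nM, with an expected range of 3500 nM to 14000 nM.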

Compound 3, half-maximal inhibitory concentration: 8500 nM
Compound 3: the middle estimate sits 1.2-fold (0.08 log units) below what was measured; low and high end bracket the measured number.
By their numbers in this assay, from the lowest: compounds 1, 2 and 3 (each within the scatter of the next).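

In this assay, the saturated chain carbon bound to two aromatic carbons now has a third group on record, and the reading stays within the scatter: 4-chlorophenyl in place of naphthalen-2-yl gives no change at the digits printed from compound 2 to compound 3 (within the scatter), and chloro in place of hydrogen on an aromatic carbon gives a 1.1-fold higher number from compound 1 to compound 3 (0.05 log units; within the scatter). Across compound 1, compound 2 and compound 3, neither the chloro group nor the second aromatic ring of naphthalen-2-yl separates the numbers. No available evidence bears on why. Still open, on these data alone, is whether an amine or a carboxylic acid on the phenyl ring would move the number beyond the scatter.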